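The source may hold more compounds than are shown below. What is called first, only, known or untested is meant among the compounds shown, and "the series" means these compounds.

Compound 1 `C=CC(=O)N1CCC[C@@H](n2nc(C#CCOc3ccccc3)c3c(N)ncnc32)C1`: 1800 nM
Compound 2 `C=CC(=O)N1CCC[C@@H](n2nc(C#CCOc3cccc(OC)c3)c3c(N)ncnc32)C1`: 1690 nM

In a functional assay on Raji cells (Homo sapiens) for antiproliferative activity, read by CCK-8 assay, with a stated time of 48 h (on this read-out lower numbers stand for stronger inhibition and higher numbers for weaker inhibition), compound 2 gives 1690 nM and stands level with compound 1 within the scatter. Compound 3 `C=CC(=O)N1CCC[C@@H](n2nc(C#CCOc3cccc(Cl)c3)c3c(N)ncnc32)C1` carries chloro in place of methoxy on an aromatic carbon, meta to a large group: chloro in place of methoxy on an aromatic carbon. Going by the values given here, only one measured step bears on this change. It is a 1.1-fold lower number from compound 1 to compound 2 (0.03 log units; within the scatter), methoxy in place of hydrogen on an aromatic carbon, and it stays within the scatter. This single small step gives no reason to expect a shift beyond the scatter in this assay. The estimated step is a 1.1-fold lower number from compound 2 to compound 3 (0.05 log units; within the scatter). Compound 3 is expected at 1500 nM, within an estimated range of 650 nM to 3300 nM.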

Compound 3, half-maximal inhibitory concentration: 2280 nM
Compound 3: the middle estimate sits 1.5-fold (0.18 log units) below what was measured, and the stated range covers the measured number.
By their numbers in this assay, from the lowest: compounds 2, 1 and 3 (each within the scatter of the next).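

Chloro in place of methoxy gives a 1.3-fold higher number from compound 2 to compound 3 (0.13 log units; within the scatter) in this assay, and chloro in place of hydrogen gives a 1.3-fold higher number from compound 1 to compound 3 (0.10 log units; within the scatter), both on the same aromatic carbon. Hydrogen, methoxy and chloro at this place therefore all stand level within the scatter, so a second kind of group has now left the number unmoved. No measurement is at hand that would explain this result. The compounds shown leave open whether an amine, a carboxylic acid or a longer chain on this carbon would move the number beyond the scatter.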